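The source may report more compounds than this note shows. Statements on the series, on what has been measured and on what is new or still open speak of the compounds shown alone.

Among the measured compounds shown here, compound 2 `COc1ccc(OC(=O)c2cn(-c3ccccc3)nc2-c2ccncc2)cc1` is one of only two compounds measured in a functional assay on MCF7 cells (Homo sapiens) for cytotoxicity, read by MTT assay, with a stated time of 48 h; a higher number here means a weaker inhibitor, a lower number a stronger inhibitor. In this assay compound 2 gives a limit of the assay rather than a number, > 100000 nM. Compound 1 `COc1ccc(OC(=O)c2cn(-c3ccccc3)nc2-c2cccnc2)cc1` likewise returns only a limit in this assay, > 100000 nM. The step that the two limits leave unreadable from compound 1 to compound 2 therefore has no readable size, because the limit of > 100000 nM in this assay, at which 2 of the 2 values shown sit, covers both values.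

Compound 3 `CC(C)(C)c1ccc(OC(=O)c2cn(-c3ccccc3)nc2-c2ccncc2)cc1` differs from compound 2 by tert-butyl in place of methoxy on an aromatic carbon. For the measured compounds named here, no measured step touches this exchange: the one step on record alters a different part of the shared core, and its size is hidden by the two limits. With both known values sitting at the limit, nothing points either way. Compound 3 is expected to remain near that limit, the estimated step of a number no higher from compound 2 to compound 3 (the limit leaves the size open) amounting to nothing beyond the scatter. Compound 3 is estimated at 100000 nM, within a range of 30000 nM to 300000 nM.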

Compound 3, half-maximal inhibitory concentration: 32300 nM
Estimate against measurement, compound 3: 3.1-fold (0.49 log units) above; the range from low to high includes it.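

Tert-butyl in place of methoxy, on an aromatic carbon para to a large group, gives the only readable change so far in this assay: an at least 3.0-fold lower number from compound 2 to compound 3 (0.49 log units; beyond the scatter). This shows that an exchange at this position can move the read-out beyond the scatter, which the exchange of pyridin-3-yl for pyridin-4-yl could not show, since limits hide its size. The step gives only a minimum size because compound 2 has a limit and not a number: the limit of > 100000 nM in this assay, at which 2 of the 3 values shown sit.

With only methoxy and tert-butyl compared at this position, the compounds shown cannot tell whether the change follows from tert-butyl arriving or methoxy leaving. As far as these compounds go, how a methyl, a chlorine or an amine at the same place would read remains open, as does tert-butyl paired with pyridin-3-yl.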